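The source may hold more compounds than are shown below. What is called first, only, known or untested is meant among the compounds shown, and "the series" means these compounds.

Measured compounds:
- compound 1, `O=C(NN=C(c1ccccn1)c1ccccn1)c1cccs1`: 950 nM
- compound 2, `O=C(NN=C(c1ccccn1)c1ccccn1)c1ccc([N+](=O)[O-])cc1`: 260 nM

Both compounds share the same core and differ only in the acyl part attached to the hydrazone. In an ADME assay on cells (Homo sapiens) for antiproliferative activity, read by MTT assay (a lower number here means a stronger inhibitor, a higher number a weaker inhibitor), compound 1 gives 950 nM, while compound 2 gives 260 nM, the lowest of the two numbers, with compound 1 standing a step away that is beyond the scatter.

Compound 3, `O=C(NN=C(c1ccccn1)c1ccccn1)c1ccccc1`, is not yet measured. It differs from compound 2 by hydrogen in place of nitro on an aromatic carbon. Going by the values given here, no measured pair shows this change, so its effect can only be guessed. Since the only other acyl variant, compound 1, gives a higher number than compound 2, a modest rise is expected for compound 3, and the step of a 2.3-fold higher number from compound 2 to compound 3 (0.36 log units; beyond the scatter) is the estimate made here. Compound 3 is therefore expected to give about 600 nM, with a range from 200 nM to 1800 nM.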

Compound 3, half-maximal inhibitory concentration: 3040 nM
Estimate against measurement, compound 3: 5.1-fold (0.70 log units) below; the whole stated range lies below it.
By their numbers in this assay, from the lowest: compound 2; then compound 1; then compound 3.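

In this assay, going by these compounds alone, the nitro group proves to carry much of the activity of the para-substituted ring: taking it away and leaving hydrogen gives a 12-fold higher number from compound 2 to compound 3 (1.07 log units; beyond the scatter), a large step and the first direct reading of any change at this place. The plain phenyl group also does not match the thiophen-2-yl group on the carbonyl carbon, since that exchange gives a 3.2-fold higher number from compound 1 to compound 3 (0.51 log units; beyond the scatter), a modest step but still beyond the scatter. Nothing available here offers a reason for either step.

As far as these compounds go, whether a chlorine atom, an amine or a carboxylic acid on the same aromatic carbon would keep the number low remains open. The compounds shown also leave open what a nitro group would do on the thiophen-2-yl ring, and what any change to the shared core would do.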